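Fluorine on two amide-linked cores: weak cytotoxicity

The source may hold more compounds than are shown below. What is called first, only, known or untested is meant among the compounds shown, and "the series" means these compounds.

Compound 1 `COc1ccc(-n2ccc(=O)c(C(=O)Nc3ccc(Oc4ccnc5[nH]ccc45)cc3)n2)cc1` and compound 2 `COc1ccc(-n2ccc(=O)c(C(=O)Nc3ccc(Oc4ccnc5[nH]ccc45)c(F)c3)n2)cc1` share one core, while compound 3 `Cn1ccc2c(Oc3ccc(NC(=O)c4nn(-c5ccc(Cl)cc5)ccc4=O)cc3)ccnc21` and compound 4 `Cn1ccc2c(Oc3ccc(NC(=O)c4nn(-c5ccc(Cl)cc5)ccc4=O)cc3F)ccnc21` share another; the difference between the two cores is not broken down here. In a functional assay on HepG2 cells (Homo sapiens) for cytotoxicity, read by MTT assay, with a stated time of 72 h (on this read-out higher numbers stand for weaker inhibition and lower numbers for stronger inhibition), compound 1 gives 50800 nM. Compound 2 reaches only the limit of this assay, > 60000 nM. The change fluoro in place of hydrogen on an aromatic carbon thus brings an at least 1.1-fold higher number from compound 1 to compound 2 (0.07 log units; that floor lies within the scatter). Compound 3 likewise reaches only a limit, > 60000 nM. Compound 4 carries the same change, (fluoro in place of hydrogen on an aromatic carbon). Compound 4 is expected to move from compound 3 by a step that the limit leaves unreadable from compound 3 to compound 4. This expectation rests on (the limit of > 60000 nM in this assay, at which 2 of the 3 values shown sit), which compound 3 already reaches, and on the small step seen from compound 1 to compound 2. Compound 4 is therefore estimated at 80000 nM, most likely reported only as a limit.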

Compound 4, half-maximal inhibitory concentration: > 60000 nM
Compound 4: no number, only a limit (the forecaster's own chance of this, stated with the estimate: 80%); the middle value is on the limit's open side.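

Compound 3 and compound 4 both stop at a limit in this assay, so no step between them can be read: the limit of > 60000 nM in this assay, at which 3 of the 4 values shown sit.

The compounds shown leave open whether fluoro in place of hydrogen changes cytotoxicity on the core of compound 3 at all.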